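A Chloro Substituent Enters the Amide-Bearing Ring

This account rests on a few compounds, and the source may have more. Where it says the series, first, only, none or still open, it means among the compounds named here.

Compound 1 `Cc1ccc(C(=O)Nc2cccc(C(F)(F)F)c2)cc1C#Cc1nn(CC2CCN(C)C2)c2ncnc(N)c12`: 41 nM
Compound 2 `Cc1ccc(C(=O)Nc2cccc(C(F)(F)F)c2)cc1C#Cc1nn(CC2CCN(C)CC2)c2ncnc(N)c12`: 70 nM
Compound 3 `CN1CCC(n2nc(C#Cc3cccc(C(=O)Nc4cccc(C(F)(F)F)c4)c3)c3c(N)ncnc32)CC1`: 1690 nM

In a functional assay on MDA-MB-231 cells (Homo sapiens) for antiproliferative activity, read by MTT assay, with a stated time of 72 h (a higher number here means a weaker inhibitor, a lower number a stronger inhibitor), compound 3 stands highest of the three numbers, well beyond the scatter from compound 2 and from compound 1. Compound 4 `CN1CCC(n2nc(C#Cc3cc(C(=O)Nc4cccc(C(F)(F)F)c4)ccc3Cl)c3c(N)ncnc32)CC1` differs from compound 3 by chloro in place of hydrogen on an aromatic carbon. For the measured compounds named here, the only measured step, a 1.7-fold higher number from compound 1 to compound 2 (0.23 log units; within the scatter), concerns the saturated amine ring on the other side of the shared core and does not touch the ring that carries the amide, so no measured step bears on this change. With nothing to guide a direction, the step to compound 4 is expected to stay within the scatter, a 1.1-fold lower number from compound 3 to compound 4 (0.05 log units; within the scatter). Compound 4 is therefore estimated at 1500 nM, with a range from 400 nM to 6000 nM.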

Compound 4, half-maximal inhibitory concentration: 749 nM
For compound 4 the middle estimate is 2.0-fold (0.30 log units) above the measured one, within the range that was stated.
By their numbers in this assay, from the lowest: compounds 1 and 2 (each within the scatter of the next); then compound 4; then compound 3.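

In this assay chloro in place of hydrogen on this aromatic carbon, ortho to a large group and para to a large group, gives a 2.3-fold lower number from compound 3 to compound 4 (0.35 log units; beyond the scatter) and thus shows that this position of the amide-bearing ring responds to a single added chlorine. The earlier step, confined to the saturated amine ring, could not show this. Nothing measured here accounts for the shift. The compounds shown leave open whether bromo or methoxy on the same carbon would give a larger or smaller step, and whether chloro would act alike alongside 1-methylpyrrolidin-3-yl.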